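The source may hold more compounds than are shown below. What is called first, only, known or untested is meant among the compounds shown, and "the series" means these compounds.

Among the compounds with values here, compound 2 `Cc1cc(NCCN2CCCC2)nc2ccc(NC(=O)c3ccc(Cl)c(Cl)c3)cc12` gives 1280 nM in a functional assay on MCF7 cells (Homo sapiens) for antiproliferative activity, read by MTT assay, with a stated time of 72 h (on this read-out lower numbers stand for stronger inhibition and higher numbers for weaker inhibition), the lowest of the two numbers measured so far. Compound 1 `Cc1cc(N(C)C)nc2ccc(NC(=O)c3ccc(Cl)c(Cl)c3)cc12` gives 33300 nM in this assay. Within the data shown here, the single measured step is a 26-fold lower number from compound 1 to compound 2 (1.42 log units; beyond the scatter), which swaps the entire substituent on the aromatic nitrogen. Compound 3 `Cc1cc(NCCN2CCCCC2)nc2ccc(NC(=O)c3ccc(Cl)c(Cl)c3)cc12` differs from compound 2 by piperidin-1-yl in place of pyrrolidin-1-yl on a saturated chain carbon, two bonds along the chain from a nitrogen on an aromatic ring. Among the measured compounds shown here, no measured step bears directly on this change of saturated ring size, and the one step available is of a different kind, so no step beyond the scatter is expected in this assay: a 1.0-fold higher number from compound 2 to compound 3 (0.01 log units; within the scatter). The estimate for compound 3 is 1300 nM, with a range from 500 nM to 3500 nM.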

Compound 3, half-maximal inhibitory concentration in the MCF7 assay: 1190 nM
Compound 3: middle estimate off by 1.1-fold (0.04 log units), on the high side; the measured number falls inside the stated range.
By their numbers in the MCF7 assay, from the lowest: compounds 3 and 2 (each within the scatter of the next); then compound 1.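

In the MCF7 assay, enlarging the ring at the chain end from pyrrolidin-1-yl to piperidin-1-yl changes little: a 1.1-fold lower number from compound 2 to compound 3 (0.03 log units; within the scatter). The large difference from dimethylamino holds with either ring, with a 28-fold lower number from compound 1 to compound 3 (1.45 log units; beyond the scatter). In a physicochemical assay for lipophilicity, at pH 7.4 (on this read-out higher numbers stand for higher lipophilicity and lower numbers for lower lipophilicity), compound 2 gives 1.72 and compound 3 gives 2.72, with a number 1.00 log units higher from compound 2 to compound 3 (beyond the scatter), so for this pair the distribution coefficient separates while the antiproliferative number does not.

Open, from the compounds shown here alone, is whether morpholin-4-yl at the chain end, or a longer chain carrying pyrrolidin-1-yl, would hold the number in the MCF7 assay.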